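A few compounds are considered here, and "the series" means these few. Any claim that something is new, unique, unknown or untested is made for them only; others in the source may bear on it.

Of the compounds shown here, two from this series have been tested in a functional assay on HCT-15 cells (Homo sapiens) for cytotoxicity, read by CCK-8 assay and cell counting, with a stated time of 72 h; on this read-out higher numbers stand for weaker inhibition and lower numbers for stronger inhibition. Compound 1, with the structure `COc1ccc(-c2cc3ccccc3c(-c3cccc(OC)c3)n2)cc1`, gives 1300 nM in this assay. Compound 2, with the structure `COc1cccc(-c2nc(-c3ccc(OC)c(OC)c3)cc3cc(C)ccc23)c1`, gives 1840 nM in this assay. Of the two numbers, that of compound 2 is the higher one, but the gap between compound 2 and compound 1 lies within the usual scatter of repeated measurements, so the two compounds cannot be ranked against each other on these data.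

Compound 3, with the structure `COc1ccc(-c2nc(-c3ccc(OC)c(OC)c3)cc3cc(C)ccc23)cc1`, has not yet been measured in this assay. It differs from compound 2 in a single respect: 4-methoxyphenyl in place of 3-methoxyphenyl on an aromatic carbon. For the measured compounds named here, no measured pair in this set isolates such a change, so its effect is unknown here. The two measured compounds carry differently placed methoxy groups yet sit within the scatter of each other, which gives no sign of a large response to such variation. For compound 3 the step of a 1.2-fold lower number from compound 2 to compound 3 (0.09 log units; within the scatter) is therefore expected to be small and not beyond the scatter, in no clear direction. Compound 3 is expected to give about 1500 nM in this assay, with a likely range from 500 nM to 4500 nM.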

Compound 3, half-maximal inhibitory concentration: 28700 nM
Compound 3: middle estimate off by 19-fold (1.28 log units), on the low side, and the stated range ends below it.
By their numbers in this assay, from the lowest: compounds 1 and 2 (each within the scatter of the next); then compound 3.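

In this assay, 4-methoxyphenyl in place of 3-methoxyphenyl on the aromatic carbon next to the ring nitrogen gives a 16-fold higher number from compound 2 to compound 3 (1.19 log units; beyond the scatter), a large loss of inhibition from a change that leaves the heavy atoms and the counts of donors and acceptors of the group the same. Compounds 1 and 2 both carry 3-methoxyphenyl at this place, so they could not show that the position responds at all to where the methoxy group sits on the phenyl ring; compound 3 shows that it responds strongly. Nothing measured here accounts for the size of this step.

Going by these compounds, whether a plain phenyl, a hydroxyl-bearing phenyl or an amine-bearing phenyl on this carbon would stay with compound 2 or drop towards compound 3 remains open. Also open, on these data alone, is whether 4-methoxyphenyl would bring the same loss on the core of compound 1, where the other aryl group and the substitution of the fused ring differ from those of compound 2.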